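A few compounds are considered here, and "the series" means these few. Any claim that something is new, unique, unknown or untested is made for them only; others in the source may bear on it.

Measured compounds:
compound 1, `N#Cc1ccc(Nc2nc(Oc3ccnc4ccccc34)nc(N3CCN(c4ccc(F)cc4)CC3)n2)cc1C(F)(F)F`: in a functional assay on DU-145 cells (Homo sapiens) for cytotoxicity, read by sulforhodamine B assay, with a stated time of 48 h (on this read-out lower numbers stand for stronger inhibition of growth and higher numbers for weaker inhibition of growth), compound 1 gives > 100000 nM, a limit of the assay rather than a number.
compound 2, `CN1CCN(c2nc(Nc3ccc(C#N)c(C(F)(F)F)c3)nc(Oc3ccnc4ccccc34)n2)CC1`: in this assay compound 2 gives > 100000 nM, again a limit and not a number.

Compound 2 therefore stands at the edge of what this assay can report, with no measured growth inhibition below that edge. Among the measured compounds shown here, the one step between measured compounds, a step that the two limits leave unreadable from compound 1 to compound 2, cannot be sized, because both of its ends rest at the limit of > 100000 nM in this assay, at which 2 of the 2 values shown sit. Compound 3, `N#Cc1ccc(Nc2nc(Oc3ccnc4ccccc34)nc(N3CCN(c4ccccn4)CC3)n2)cc1C(F)(F)F`, is not yet measured; it differs from compound 2 by pyridin-2-yl in place of methyl on an amine nitrogen in a ring. For the measured compounds named here, the only step that bears on this change is the unreadable one from compound 1 to compound 2, which swapped a 4-fluorophenyl for a methyl on the same ring nitrogen without either compound leaving the limit. Compound 1 already shows that an aromatic ring on that nitrogen gives no readable inhibition here. The expected step in this assay is therefore none beyond the scatter, a step that the limit leaves unreadable from compound 2 to compound 3, with compound 3 most likely also returning only a limit. Compound 3 is estimated at 150000 nM in this assay, within a range of 30000 nM to 1000000 nM.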

Compound 3, concentration for total growth inhibition: > 100000 nM
Compound 3 was reported as a limit; the forecaster's own chance of this, stated with the estimate: 85%; the middle value does not contradict the limit.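

Compound 3 joins compound 1 and compound 2 at the edge of the read-out, so no step among these three compounds can be read, because each value is a limit and not a number: the limit of > 100000 nM in this assay, at which 3 of the 3 values shown sit.

The compounds shown leave open whether methyl, 4-fluorophenyl and pyridin-2-yl on that ring nitrogen differ at all in this assay.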